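A few compounds are considered here, and "the series" means these few. Any claim that something is new, unique, unknown or untested is made for them only; others in the source may bear on it.

Compound 1 `O=C(c1cccc(F)c1)N1CC(c2nc(-c3cccc(Cl)c3)no2)C1` gives 780 nM in an assay on HEK293 cells for negative allosteric modulation of metabotropic glutamate receptor 5 (Homo sapiens), read by FLIPR; on this read-out lower numbers stand for stronger inhibition and higher numbers for weaker inhibition. Compound 2 `O=C(C1CCC1)N1CC(c2nc(-c3cccc(Cl)c3)no2)C1` gives 1500 nM in this assay, and the difference is a 1.9-fold higher number from compound 1 to compound 2 (0.28 log units; within the scatter). Compound 3 `O=C(C1CCC(F)(F)CC1)N1CC(c2nc(-c3cccc(Cl)c3)no2)C1` reaches only a limit of the assay in this assay, > 10000 nM, so it stands at the weak end of the three, a position set by the limit of > 10000 nM in this assay, at which 1 of the 3 values shown sits. The steps of an at least 12-fold higher number from compound 1 to compound 3 (1.10 log units; beyond the scatter) and an at least 6.6-fold higher number from compound 2 to compound 3 (0.82 log units; beyond the scatter) both end at that limit, so only their lower bounds are known. Compound 4 `CC1CCN(C(=O)N2CC(c3nc(-c4cccc(Cl)c4)no3)C2)CC1` differs from compound 3 by 4-methylpiperidin-1-yl in place of 4,4-difluorocyclohexyl on a carbonyl carbon, one six-membered non-aromatic ring replacing another on the carbonyl carbon. The measured steps bear on this change only loosely: they show that exchanging the group on this carbonyl carbon shifted the number by modest to large amounts, and that the 4,4-difluorocyclohexyl group gave the weakest result. Because compound 3 sits at the limit > 10000 nM, the step of an at least 1.2-fold lower number from compound 3 to compound 4 (0.09 log units; that floor lies within the scatter) is expected to be uncertain and probably small. Compound 4 is therefore estimated at 8000 nM in this assay, within 2000 nM to 30000 nM, with a fair chance that only a limit is again reported.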

Compound 4, half-maximal inhibitory concentration: > 10000 nM
Compound 4: no number, only a limit (the forecaster's own chance of this, stated with the estimate: 50%); middle value at least 1.2-fold (0.09 log units) from the limit.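

In this assay compound 4 gives > 10000 nM, which is a limit of the assay and not a number. With 4-methylpiperidin-1-yl on this carbonyl carbon, the result is again far from those of the 3-fluorophenyl and cyclobutyl compounds, as an at least 12-fold higher number from compound 1 to compound 4 (1.10 log units; beyond the scatter) and an at least 6.6-fold higher number from compound 2 to compound 4 (0.82 log units; beyond the scatter) show, so the loss is not confined to the 4,4-difluorocyclohexyl group. The step between compound 3 and compound 4 cannot be read, because both ends are limits: the limit of > 10000 nM in this assay, at which 2 of the 4 values shown sit.

On these data alone, how far compound 3 and compound 4 actually differ, and whether the ring nitrogen plays any part, remains open. Also open, as far as these compounds go, is whether a smaller amine on this carbonyl carbon, such as pyrrolidin-1-yl, would return a measurable value.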